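Ester chain length and growth inhibition in the aryl ester series

The compounds below may be only part of what the source reports. "The series", "measured", "known", "first", "only" and "open" are said of these compounds alone.

In a functional assay on MCF7 cells (Homo sapiens) for inhibition, with a stated time of 48 h, tested at 50 uM (a lower number here means less inhibition of growth, a higher number more inhibition of growth at the concentration tested), compound 1 `C=C[C@@](C)(/C=C/c1ccc(OC(C)=O)cc1)CCC=C(C)C` gives 75%. Compound 2 `C=C[C@@](C)(/C=C/c1ccc(OC(=O)CCC)cc1)CCC=C(C)C` gives 20% in this assay, and compound 3 `C=C[C@@](C)(/C=C/c1ccc(OC(=O)CCCCCCC)cc1)CCC=C(C)C` gives 12% in this assay. The change ethyl in place of hydrogen on a saturated chain carbon bound to a carbonyl carbon made the step of a number 55 percentage points lower from compound 1 to compound 2 (beyond the scatter). The cores of compound 1 and compound 3 differ by hexyl in place of hydrogen on a saturated chain carbon bound to a carbonyl carbon, with the step of a number 63 percentage points lower from compound 1 to compound 3 (beyond the scatter). Between the two longer esters the step of a number 8 percentage points lower from compound 2 to compound 3 (within the scatter) shows no difference that can be read.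

Compound 4 `C=C[C@@](C)(/C=C/c1ccc(OC(=O)CCCCCCCCC)cc1)CCC=C(C)C` has not been measured. It differs from compound 3 by ethyl in place of hydrogen on a saturated chain carbon, seven bonds along the chain from a carbonyl carbon. This is the same kind of change as that made from compound 1 to compound 2, but the place differs: there the ethyl entered on a saturated chain carbon bound to a carbonyl carbon, here it enters on a saturated chain carbon seven bonds along the chain from a carbonyl carbon. A step of only a number 4 percentage points lower from compound 3 to compound 4 (within the scatter) is expected in this assay, because the earlier lengthening gave a number 8 percentage points lower from compound 2 to compound 3 (within the scatter). Compound 4 is therefore estimated at 8% in this assay. For compound 4 the expected range runs from 0% to 20%.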

Compound 4, percent growth inhibition at one concentration: 10%
For compound 4 the middle estimate is 2 percentage points below the measured one; the range from low to high includes it.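

In this assay the ethyl change does not carry over from one core to another: the same change on two cores in this assay, a number 55 percentage points lower (beyond the scatter) from compound 1 to compound 2 and a number 2 percentage points lower (within the scatter) from compound 3 to compound 4, 53 percentage points apart, beyond the scatter of two such steps.
The hexyl change does not carry over either: the same change on two cores in this assay, a number 63 percentage points lower (beyond the scatter) from compound 1 to compound 3 and a number 10 percentage points lower (within the scatter) from compound 2 to compound 4, 53 percentage points apart, beyond the scatter of two such steps.
A large step appears only where the shortest ester is the starting point, with a number 65 percentage points lower from compound 1 to compound 4 (beyond the scatter) against a number 2 percentage points lower from compound 3 to compound 4 (within the scatter) and a number 10 percentage points lower from compound 2 to compound 4 (within the scatter), but these four compounds do not show why the same change differs so much between cores, nor whether this holds outside this ester series.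

The compounds shown leave open whether a single added methyl on the shortest ester already gives a large step, or whether it takes the full ethyl. Also open, as far as these compounds go, is how an ester chain carrying an amine or a carboxylic acid would read in this assay, and whether a branched chain would follow the straight chains.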